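Fluorine on the Benzamide Ring of Compound 2

The source may report more compounds than this note shows. Statements on the series, on what has been measured and on what is new or still open speak of the compounds shown alone.

Of the compounds shown here, two have so far been measured in a functional assay on PC-3 cells (Homo sapiens) for antiproliferative activity; a lower number here means a stronger inhibitor of growth, a higher number a weaker inhibitor of growth. Compound 1 `COc1cccc(-c2nn(-c3ccccc3)cc2-c2ccnc(NCCNC(=O)Nc3cccc(C(F)(F)F)c3)c2)c1` gives 2020 nM in this assay. Compound 2 `O=C(NCCCNc1cc(-c2cn(-c3ccccc3)nc2-c2cccc(O)c2)ccn1)c1ccccc1` gives 2100 nM in this assay. Compound 2 holds the highest of the two numbers, but compound 1 lies within the scatter of it, so the two cannot be told apart on these data.

Compound 3 `O=C(NCCCNc1cc(-c2cn(-c3ccccc3)nc2-c2cccc(O)c2)ccn1)c1ccc(F)cc1` differs from compound 2 in one place: fluoro in place of hydrogen on an aromatic carbon. In words, fluoro in place of hydrogen on an aromatic carbon, which turns the benzamido group of compound 2 into a ((4-fluorophenyl)carbonyl)amino group.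

Within the data shown here, no step between two measured compounds is available to show how this change plays out in this assay, and the two measured numbers stand close together. The expectation for compound 3 is therefore a step within the scatter, a 1.2-fold lower number from compound 2 to compound 3 (0.07 log units; within the scatter), with no clear direction. Compound 3 is estimated at 1800 nM in this assay, in a range from 700 nM to 4500 nM.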

Compound 3, concentration for 50% growth inhibition: 2810 nM
Beside the measured number, compound 3's estimate is 1.6-fold (0.19 log units) below it; the measured number falls inside the stated range.
By their numbers in this assay, from the lowest: compounds 1, 2 and 3 (each within the scatter of the next).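

In this assay, among these compounds, this is the first reading of a single change, with a 1.3-fold higher number from compound 2 to compound 3 (0.13 log units; within the scatter) for fluoro in place of hydrogen on the aromatic ring of the benzamido group. At this carbon, para to a large group, compound 2 and compound 3 cannot be told apart, so the position accepts a fluoro without any readable shift and no direction can be assigned to the change. No measured finding bears on this result, and the data offer no account of it.

As far as these compounds go, a single fluoro says little about the position as a whole, so it remains open whether methoxy, trifluoromethyl or a dimethylamino group at the same carbon would carry the number beyond the scatter, and whether a fluoro on another carbon of the same ring would do so. Also open, from the compounds shown here alone, is what a carboxylic acid on this ring would do, and whether a shorter or longer chain in place of the one joining the amide to the shared core would change the reading of this fluoro step.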